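Ester in place of morpholine amide on the acrylamide arm

The compounds below may be only part of what the source reports. "The series", "measured", "known", "first", "only" and "open" are said of these compounds alone.

Going by the values given here, compound 3 `O=C(/C=C/c1ccncc1-c1ccc2ccccc2c1)N1CCOCC1` gives 60.3 nM in an assay on a protein complex for inhibition of CDK8/Cyclin C (Homo sapiens), with a stated time of 1 h (on this read-out lower numbers stand for stronger inhibition and higher numbers for weaker inhibition), and is the only compound of this group with a reported number. For compound 1 `NNC(=O)COc1ccncc1-c1ccc2ccccc2c1` the entry reads "not determined" (no result reported), and for compound 2 `COC(=O)COc1ccncc1-c1ccc2ccccc2c1` the entry likewise reads "not determined" (no result reported), so no comparison with compound 3 is possible from them. Compound 4 `CCOC(=O)/C=C/c1ccncc1-c1ccc2ccccc2c1` keeps the shared core of compound 3 and differs in one place: ethoxy in place of morpholin-4-yl on a carbonyl carbon. Among the compounds with values here, no pair of measured compounds shows a step of this kind. In this assay a modest weakening is expected, probably somewhat beyond the scatter. Compound 4 is estimated at 130 nM, within 45 nM to 400 nM; the expected step of a 2.2-fold higher number from compound 3 to compound 4 (0.33 log units; beyond the scatter) is thus a loss.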

Compound 4, half-maximal inhibitory concentration: 53.3 nM
Estimate against measurement, compound 4: 2.4-fold (0.39 log units) above; the measured number falls inside the stated range.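

In this assay, replacing morpholin-4-yl with ethoxy on the carbonyl carbon gives a 1.1-fold lower number from compound 3 to compound 4 (0.05 log units; within the scatter). This first comparison at this position shows that the ring is not required to keep the number: the ester and the morpholine amide read alike here. Nothing available bears on why they do. Going by these compounds, whether a carboxylic acid or a longer chain on this carbonyl carbon would read the same stays open. A single pair cannot show how wide this tolerance is.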